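The source may report more compounds than this note shows. Statements on the series, on what has been measured and on what is new or still open speak of the compounds shown alone.

Measured in a functional assay on Lewis lung carcinoma cells (Mus musculus) for antiproliferative activity, read by MTT assay, with a stated time of 24 h; a lower number here means a stronger inhibitor, a higher number a weaker inhibitor:
Compound 1 `C=CCc1cc(-c2ccccc2)ccc1O`: > 100000 nM (a limit)
Compound 2 `C=CCc1cc(-c2ccc(OC)cc2)ccc1O`: > 100000 nM (a limit)

Compound 2 stands only at a limit, > 100000 nM, and has no readable number. Compound 1 also gives only a limit. The next analogue is compound 3 `C=CCc1cc(-c2ccc(C(F)(F)F)cc2)ccc1O`, which carries trifluoromethyl in place of methoxy on an aromatic carbon, para to a large group: trifluoromethyl in place of methoxy on an aromatic carbon.

For the measured compounds named here, the one measured step that bears on this change is a step that the two limits leave unreadable from compound 1 to compound 2, also a change on an aromatic carbon, and its size cannot be read. Going by the values given here, the series so far offers only (the limit of > 100000 nM in this assay, at which 2 of the 2 values shown sit). No measured size or direction therefore carries over to this assay, and no step beyond the scatter is expected. The expected step is a number no higher from compound 2 to compound 3 (the limit leaves the size open). A further limit is the likeliest expected outcome for compound 3. For compound 3 the estimate is 100000 nM, with an expected range of 40000 nM to 200000 nM.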

Compound 3, half-maximal inhibitory concentration: 74800 nM
For compound 3 the middle estimate is 1.3-fold (0.13 log units) above the measured one, and the stated range covers the measured number.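

In this assay, for the compounds shown here, compound 3 gives 74800 nM, the first readable number, so the aromatic carbon para to a large group now has a value. Trifluoromethyl in place of methoxy gives an at least 1.3-fold lower number from compound 2 to compound 3 (0.12 log units; that floor lies within the scatter), and trifluoromethyl in place of hydrogen gives an at least 1.3-fold lower number from compound 1 to compound 3 (0.12 log units; that floor lies within the scatter); neither floor establishes a change beyond the scatter, and the step between the two earlier compounds cannot be read. Most of the series still rests on limits: the limit of > 100000 nM in this assay, at which 2 of the 3 values shown sit.

On these data alone, whether an amine, a carboxylic acid or a nitrile on this carbon would give a number clearly lower than that of compound 3 remains open. Also open, as far as these compounds go, is whether a longer chain elsewhere on the shared core would bring a larger step than any change at this carbon.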